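This account rests on a few compounds, and the source may have more. Where it says the series, first, only, none or still open, it means among the compounds named here.

In a functional assay on cells (Platelet, Oryctolagus cuniculus) for inhibition, read by turbidimetry, with a stated time of 3 min, tested at 100 ug/mL (a higher number here means a weaker effect of the compound at the concentration tested, a lower number a stronger effect), compound 1 `C/C=C/C=C/C=C\CC/C=C/C=C/C(=O)NC(C)C` gives 72.7%, and compound 2 `COc1ccc(-c2oc3c(OC)c(OC)cc(O)c3c(=O)c2O)cc1` gives 78.6%. These two readings of compound 2 and compound 1 sit within the usual scatter of each other, so nothing separates them. Compound 3 `COc1ccc(-c2oc3c(OC)c(O)cc(O)c3c(=O)c2O)cc1` is compound 2 with one change: hydrogen in place of methyl on an oxygen on an aromatic ring. Among the compounds with values here, no measured pair shows what such a change does here, so in this assay the expected step of a number 3.6 percentage points lower from compound 2 to compound 3 (within the scatter) from compound 2 to compound 3 is small, in no particular direction, and within the scatter. Compound 3 is therefore expected to give about 75%, somewhere between 60% and 90%.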

Compound 3, a percentage reported as activity, at one concentration (the size of the read-out at that concentration, not a potency): 73.3%
For compound 3 the middle estimate is 1.7 percentage points above the measured one; low and high end bracket the measured number.
By their numbers in this assay, from the lowest: compounds 1, 3 and 2 (each within the scatter of the next).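

Within the data shown here, replacing methoxy with hydroxy on this oxygen on an aromatic ring gives, in this assay, a number 5.3 percentage points lower from compound 2 to compound 3 (within the scatter) and is the first measured case of this change here. At this position, then, removing the methyl does not separate the two compounds at the single concentration tested. No available evidence bears on this result. From the compounds shown here alone, whether an ethoxy group or an amine at this position would give a reading beyond the scatter remains open. So does whether the same change on the other methoxy groups would do so.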